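The compounds below may be only part of what the source reports. "The series", "measured", "known", "first", "only" and "open" are said of these compounds alone.

Compound 1 `COc1ccc2[nH]c(-c3ccc[nH]3)c(C3CC(=O)NC3=O)c2c1` carries a methoxy on its core, and in a functional assay on PC-3 cells (Homo sapiens) for cytotoxicity, read by MTT assay, with a stated time of 72 h (a higher number here means a weaker inhibitor, a lower number a stronger inhibitor), compound 1 gives 6000 nM. Compound 3 `Cc1ccc2[nH]c(-c3ccc[nH]3)c(C3CC(=O)NC3=O)c2c1` differs from compound 1 in one place, (methyl in place of methoxy on an aromatic carbon), and in this assay compound 3 gives 11000 nM. The step of a 1.8-fold higher number from compound 1 to compound 3 (0.26 log units; within the scatter) is small. Compound 2 `COc1ccc2[nH]c(-n3cccn3)cc2c1` has a different core, and the difference between the two cores is not broken down here. In this assay compound 2 reaches only a limit of the assay, > 100000 nM. Compound 4 `Cc1ccc2[nH]c(-n3cccn3)cc2c1` is not yet measured and differs from compound 2 by the same change, (methyl in place of methoxy on an aromatic carbon). The step from compound 2 to compound 4 is expected to be about a step that the limit leaves unreadable from compound 2 to compound 4, resting on the small step of a 1.8-fold higher number from compound 1 to compound 3 (0.26 log units; within the scatter) seen between compound 1 and compound 3. For compound 4 the estimate is 150000 nM, and given the limit of > 100000 nM in this assay, at which 1 of the 3 values shown sits, it is expected that only a limit will again be reported.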

Compound 4, half-maximal inhibitory concentration: > 100000 nM
Compound 4 was reported as a limit (the forecaster's own chance of this, stated with the estimate: 85%); the middle value does not contradict the limit.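

Compound 2 and compound 4 both reach only a limit in this assay, so no step between them can be read: the limit of > 100000 nM in this assay, at which 2 of the 4 values shown sit.

Going by these compounds, whether methyl in place of methoxy changes anything on this core stays open.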